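Amide nitrogen substituent exchange in compound 4

The source may hold more compounds than are shown below. What is called first, only, known or untested is meant among the compounds shown, and "the series" means these compounds.

Compound 1 `COc1ccc(C(=O)Nc2c(F)cccc2F)cc1OC1CCCC1` gives 70 nM in an assay on isolated protein for inhibition of phosphodiesterase 4A (Sus scrofa) (a lower number here means a stronger inhibitor, a higher number a weaker inhibitor), the lowest number among the three measured compounds. Compound 2 `COc1ccc(C(=O)Nc2c(F)cccc2F)cc1` gives 37000 nM, and compound 3 `O=C(Nc1c(F)cccc1F)c1cccc(OC2CCCC2)c1` gives 15000 nM. Both measured steps start from compound 1 and remove one of its two alkoxy groups: a 530-fold higher number from compound 1 to compound 2 (2.72 log units; beyond the scatter), and a 210-fold higher number from compound 1 to compound 3 (2.33 log units; beyond the scatter). Each is a large loss, well beyond the scatter, so the pair of alkoxy groups on the shared core carries most of what compound 1 shows.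

Compound 4 `COc1ccc(C(=O)Nc2c(Br)cncc2Br)cc1OC1CCCC1` keeps both alkoxy groups unchanged and differs from compound 1 only at the amide nitrogen: 3,5-dibromopyridin-4-yl in place of 2,6-difluorophenyl on an amide-type nitrogen. Among the compounds with values here, no measured step touches this part of the molecule, so the two steps from compound 1 give no direct guide to direction or size here; they only say that the part responsible for the large losses is retained. Within the data shown here, with no step at the amide nitrogen to rest on, the expectation is no change beyond the scatter, with a wide allowance either way: compound 4 is estimated at 40 nM, within 6 nM to 250 nM. This estimate amounts to an expected 1.8-fold lower number from compound 1 to compound 4 (0.24 log units; within the scatter).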

Compound 4, half-maximal inhibitory concentration: 7 nM
Estimate against measurement, compound 4: 5.7-fold (0.76 log units) above, and the stated range covers the measured number.
By their numbers in this assay, from the lowest: compound 4; then compound 1; then compound 3; then compound 2.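

In this assay the amide-type nitrogen now has a measured step of its own: 3,5-dibromopyridin-4-yl in place of 2,6-difluorophenyl (a 10-fold lower number from compound 1 to compound 4 (1.00 log units; beyond the scatter)) moves the number beyond the scatter with both alkoxy groups kept. The earlier steps shown here showed only losses on removing an alkoxy group (a 530-fold higher number from compound 1 to compound 2 (2.72 log units; beyond the scatter); a 210-fold higher number from compound 1 to compound 3 (2.33 log units; beyond the scatter)), whereas this change at a separate part of the molecule lowers the number, so the position is not neutral in this pair, though the step is smaller than either loss. The exchange changes the ring and its halogens at once, adding a ring nitrogen and replacing both fluorine atoms with bromine atoms, and no measurement here explains the gain or divides it between those changes.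

A dibromophenyl group, which has bromine without the ring nitrogen, and a difluoropyridinyl group, which has the ring nitrogen without bromine, would separate the two parts of the step. From the compounds shown here alone, whether the gain holds when cyclopentyloxy is replaced by a butoxy chain also remains open.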